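This account rests on a few compounds, and the source may have more. Where it says the series, first, only, none or still open, it means among the compounds named here.

Measured in a functional assay on DU-145 cells (Homo sapiens) for inhibition, read by trypan blue exclusion, with a stated time of 96 h; on this read-out higher numbers stand for weaker inhibition of growth and lower numbers for stronger inhibition of growth:
compound 1 `Cc1ccc(/C=C(\C(=O)c2ccc(Cl)cc2)S(=O)(=O)Cc2ccc(F)cc2)s1` gives 50000 nM
compound 2 `Cc1ccc(/C=C(\C(=O)c2ccc(Br)cc2)S(=O)(=O)Cc2ccc(F)cc2)s1` gives 1000 nM
compound 3 `Cc1ccc(S/C(=C/c2c[nH]c3ccc(Cl)cc23)C(=O)c2ccc(Cl)cc2)cc1` gives 1000 nM

Compound 1 and compound 2 share one core and differ in a single place, (bromo in place of chloro on an aromatic carbon). That change made a step of a 50-fold lower number from compound 1 to compound 2 (1.70 log units; beyond the scatter). Compound 3 rests on a different core; the difference between the two cores is not broken down here. In this assay compound 3 stands level with compound 2 at the digits recorded, and together the two give the lowest numbers of the three.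

Compound 4 `Cc1ccc(S/C(=C/c2c[nH]c3ccc(Br)cc23)C(=O)c2ccc(Cl)cc2)cc1` has not been measured. It differs from compound 3 by bromo in place of chloro on an aromatic carbon. This is the same kind of change as between compound 1 and compound 2, bromo in place of chloro on an aromatic carbon, but not the same change: in compound 2 the aromatic carbon belongs to a six-membered aromatic ring of carbon only, para to a large group, whereas in compound 4 it belongs to a six-membered aromatic ring of carbon only that is part of a fused or bridged system of two rings, meta to a fused ring and para to a fused ring. Among these compounds the change occurs only in these two pairs, one of them measured.

Going by the values given here, a step as large as the measured one is not expected, since the single instance a 50-fold lower number from compound 1 to compound 2 (1.70 log units; beyond the scatter) sits on another core and at another place. A smaller step in the same direction is expected from compound 3 to compound 4 in this assay, a 2.0-fold lower number from compound 3 to compound 4 (0.30 log units; within the scatter), resting on a 50-fold lower number from compound 1 to compound 2 (1.70 log units; beyond the scatter) and on the different place of the change. Compound 4 is therefore estimated at 500 nM, expected to fall between 80 nM and 2500 nM.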

Compound 4, concentration for 50% growth inhibition: 1000 nM
The estimate for compound 4 lay 2.0-fold (0.30 log units) below the measured number; measured number inside the range.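

In this assay, bromo in place of chloro on an aromatic carbon gave no change at the digits printed from compound 3 to compound 4 (within the scatter), so the large step seen on the core of compound 1 did not reappear on the core of compound 3: the same change on two cores in this assay, a 50-fold lower number (1.70 log units; beyond the scatter) from compound 1 to compound 2 and no change at the digits printed (within the scatter) from compound 3 to compound 4, 50-fold (1.70 log units) apart, beyond the scatter of two such steps

In this series, therefore, the size of this step on one core is no reliable guide to its size on the other, and a gain measured on one core should not be assumed on the other. This does not show which difference matters, since the two pairs differ both in core and in the place of the change, and two pairs cannot separate these or support a general rule for the series.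

Still open, on these data alone, is whether the same swap at the other chloro of compound 4, which sits where the bromo of compound 2 sits relative to the carbonyl, would reproduce the large step on this core. Also open is how the place that carries bromo in compound 4 would respond to a group of a different kind, such as iodo, methoxy or an amine, since only chloro and bromo appear there in the compounds shown.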